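The source may hold more compounds than are shown below. What is called first, only, known or untested is meant among the compounds shown, and "the series" means these compounds.

Within the data shown here, in an assay on Prostate gland for inhibition of steroid 5-alpha-reductase (Rattus norvegicus) (a lower number here means a stronger inhibitor, a higher number a weaker inhibitor), compound 2 `C/C(=C\C(=O)Nc1ccccc1OCCCC(=O)O)c1ccc2c(ccn2C(C(C)C)C(C)C)c1` gives 14 nM, the lowest of the two numbers so far, while compound 1 `C/C(=C\C(=O)Nc1ccccc1OCCCC(=O)O)c1ccc2c(ccn2CC(C)C)c1` gives 160 nM. Among the measured compounds shown here, the one measured step, an 11-fold lower number from compound 1 to compound 2 (1.06 log units; beyond the scatter), came from enlarging the group on the aromatic nitrogen. Compound 3 `C/C(=C\C(=O)Nc1ccccc1OCCCC(=O)O)c1ccc2c(ccn2Cc2ccccc2C)c1` differs from compound 2 by 2-methylbenzyl in place of 1-isopropyl-2-methylpropyl on an aromatic nitrogen. That step bears on this change only loosely: a branched chain is swapped for a ring rather than grown, so the gain need not carry over. A moderate rise in the number is expected, a 2.9-fold higher number from compound 2 to compound 3 (0.46 log units; beyond the scatter). Compound 3 is therefore estimated at 40 nM, within 10 nM to 160 nM.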

Compound 3, half-maximal inhibitory concentration: 69 nM
Compound 3: middle estimate off by 1.7-fold (0.24 log units), on the low side; the range from low to high includes it.
By their numbers in this assay, from the lowest: compound 2; then compound 3; then compound 1.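

In this assay, the position on the aromatic nitrogen accepts a ring as well as a branched chain: 2-methylbenzyl gives a 2.3-fold lower number from compound 1 to compound 3 (0.37 log units; beyond the scatter). It still falls short of 1-isopropyl-2-methylpropyl, with a 4.9-fold higher number from compound 2 to compound 3 (0.69 log units; beyond the scatter), although it carries more heavy atoms, so heavy-atom count alone does not set the order here. No measurement available here explains that order. Still open, going by these compounds, is whether plain benzyl or cyclohexylmethyl would match the branched chain, and whether a methoxy group on the ring would change the number.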